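Chloro to bromo on the pendant aryl ring

This account rests on a few compounds, and the source may have more. Where it says the series, first, only, none or still open, it means among the compounds named here.

Of the compounds shown here, three sharing one core have been measured in a functional assay on K562 cells (Homo sapiens) for inhibition, read by sulforhodamine B assay, with a stated time of 48 h, tested at 10 uM; a higher number here means more inhibition at the concentration tested (going by the name of the read-out), a lower number less inhibition. Compound 1 `c1ccc2c(-c3cn4ccnc4c(-c4ccc5ncn(C6CCCCC6)c5c4)n3)cccc2c1` gives 30.9%. Compound 2 `CC(=O)c1ccc(-c2cn3ccnc3c(-c3ccc4ncn(C5CCCCC5)c4c3)n2)cc1` gives 9.6%. Compound 3 `Clc1ccc(-c2cn3ccnc3c(-c3ccc4ncn(C5CCCCC5)c4c3)n2)cc1` gives 44.5%, the highest of the three numbers, and its margin over each of the others lies beyond the scatter. The steps among them are as follows: a number 21.3 percentage points lower from compound 1 to compound 2 (beyond the scatter); a number 13.6 percentage points higher from compound 1 to compound 3 (beyond the scatter); a number 34.9 percentage points higher from compound 2 to compound 3 (beyond the scatter).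

Compound 4 `Brc1ccc(-c2cn3ccnc3c(-c3ccc4ncn(C5CCCCC5)c4c3)n2)cc1` differs from compound 3 in one place: bromo in place of chloro on an aromatic carbon. Going by the values given here, no measured step swaps one halogen for another. The two steps that end at compound 3, from compound 1 and from compound 2, change the whole group on that aromatic carbon, and they were modest and large in this assay, whereas the change to compound 4 exchanges one single-atom substituent for another of the same kind at the same place. He therefore expects no step beyond the scatter, with the number for compound 4 estimated at about the level of compound 3, perhaps a little higher: a number 3.5 percentage points higher from compound 3 to compound 4 (within the scatter). Compound 4 is estimated to give 48% in this assay, expected to fall between 30% and 66%.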

Compound 4, a percentage reported as inhibition, at one concentration (the size of the read-out at that concentration, not a potency): 59%
Compound 4: middle estimate off by 11 percentage points, on the low side, within the range that was stated.
By their numbers in this assay, from the lowest: compound 2; then compound 1; then compound 3; then compound 4.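

In this assay, going by these compounds alone, exchanging one halogen for another on an aromatic carbon para to a large group gives a number 14.5 percentage points higher from compound 3 to compound 4 (beyond the scatter), so this place tells chloro and bromo apart, something the earlier compounds could not show because none of their steps swapped one halogen for another. Compound 4 also extends the lead of the 4-halophenyl compounds, with a number 49.4 percentage points higher from compound 2 to compound 4 (beyond the scatter) and with a number 28.1 percentage points higher from compound 1 to compound 4 (beyond the scatter), which places 4-bromophenyl above every other group shown at this position and makes the acetyl-to-bromo step the largest of the set. Nothing on hand explains why bromo gives the higher number here.

The compounds shown leave open whether the rise from chloro to bromo carries on to iodo or whether fluoro would fall below chloro, and where a methoxy group or an amine on the same carbon would stand against the halogens. Going by these compounds, each number is also the size of the read-out at a single concentration, so how compound 3 and compound 4 compare in potency remains open.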